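This account rests on a few compounds, and the source may have more. Where it says the series, first, only, none or still open, it means among the compounds named here.

Compound 1 `Cc1nc(-c2ccccc2)c(C(=O)N2CCN(c3ccc(C(F)(F)F)cc3)CC2)o1` was tested in a functional assay on HL-60 cells (Homo sapiens) for inhibition, read by MTT assay, with a stated time of 72 h; on this read-out lower numbers stand for stronger inhibition and higher numbers for weaker inhibition. In this assay compound 1 gives > 1000 nM, which is a limit of the assay rather than a measured number. Compound 2 `Cc1nc(-c2cccc(OP(=O)(O)O)c2)c(C(=O)N2CCN(c3cccc(Cl)c3)CC2)o1` likewise gives > 1000 nM in this assay, again a limit. So compound 1 stands at the limit of > 1000 nM in this assay, at which 2 of the 2 values shown sit, with no number of its own to compare against.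

Compound 3 `CC(=O)Nc1cccc(N2CCN(C(=O)c3oc(C)nc3-c3ccccc3)CC2)c1` has not yet been measured. It differs from compound 1 in one place: 3-acetamidophenyl in place of 4-(trifluoromethyl)phenyl on an amine nitrogen in a ring. For the measured compounds named here, no step between two measured compounds is available here, so the effect of this change has to be guessed. Because both measured compounds sit at the limit of > 1000 nM in this assay, at which 2 of the 2 values shown sit, the step expected is a step that the limit leaves unreadable from compound 1 to compound 3, that is, no shift beyond the scatter. Compound 3 is therefore expected to give about 3000 nM in this assay, within a range from 800 nM to 15000 nM.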

Compound 3, half-maximal inhibitory concentration: 329 nM
For compound 3 the middle estimate is 9.1-fold (0.96 log units) above the measured one, and the stated range ends above it.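

In this assay, putting 3-acetamidophenyl in place of 4-(trifluoromethyl)phenyl on the amine nitrogen in the ring gives an at least 3.0-fold lower number from compound 1 to compound 3 (0.48 log units; beyond the scatter). For the compounds shown here, this shows that the group at this position can change the read-out, and compound 3 is the first compound here with a measured number rather than a limit. The true size of the step remains unknown because compound 1 has only a limit, so the step gives a minimum size: the limit of > 1000 nM in this assay, at which 2 of the 3 values shown sit.

This one change alters both the group and its numbered place on the phenyl ring, and the compounds shown do not separate these two differences. As far as these compounds go, it also remains open whether a 3-aminophenyl group, with a free amine, or a phenyl group carrying a carboxylic acid would give a similar number.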